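Notes on a thiazolidinone amide series, two points measured

The compounds below may be only part of what the source reports. "The series", "measured", "known", "first", "only" and "open" are said of these compounds alone.

Two compounds have numbers in a functional assay on HOS-TE85 cells (Homo sapiens) for inhibition, read by CCK-8 assay, with a stated time of 72 h; on this read-out lower numbers stand for stronger inhibition and higher numbers for weaker inhibition. Compound 1 `CC1SC(c2cccc(C(=O)NCCCCc3ccc(Cl)cc3)c2)N(c2cccc(C3CC3)c2)C1=O` gives 932 nM. Compound 2 `COc1ccc(C)cc1N1C(=O)CSC1c1cccc(C(=O)NCCCCc2ccccc2)c1` gives 300 nM, the lowest of the two numbers; the number of compound 1 stands higher, and the gap between them lies beyond the usual scatter. Among the compounds with values here, no pair of measured compounds differs in only one place, so no single step has yet been measured in this assay.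

Compound 3 `O=C(NCCCCc1ccccc1)c1cccc(C2SCC(=O)N2c2cnccn2)c1` is not yet measured. It differs from compound 2 as follows: pyrazin-2-yl in place of 2-methoxy-5-methylphenyl on an amide-type nitrogen in a ring. Both measured compounds carry a substituted phenyl on that nitrogen, so nothing measured speaks to a heteroaryl there. In this assay a moderate weakening is expected, the expected step being a 2.7-fold higher number from compound 2 to compound 3 (0.43 log units; beyond the scatter). Compound 3 is estimated at 800 nM in this assay, within a range from 200 nM to 4000 nM.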

Compound 3, half-maximal inhibitory concentration: > 1000 nM
Compound 3: a limit, no number (the forecaster's own chance of this, stated with the estimate: 10%); at least 1.2-fold (0.09 log units) between middle value and limit.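

In this assay, compound 3 carries a limit and not a number: > 1000 nM. Pyrazin-2-yl in place of 2-methoxy-5-methylphenyl on the amide-type nitrogen in a ring gives an at least 3.3-fold higher number from compound 2 to compound 3 (0.52 log units; beyond the scatter), the first single change read in this series, and it shows that inhibition here is not indifferent to the group on this nitrogen. The step is a lower bound only, and its full size stays unread: the limit of > 1000 nM in this assay, at which 1 of the 3 values shown sits.

The compounds shown leave open whether the weakening goes with the ring nitrogens of pyrazin-2-yl or with the loss of the methoxy and methyl groups of the phenyl ring. A plain phenyl or a pyridin-2-yl on the same nitrogen, with the rest of compound 2 kept, would separate these two readings.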